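A Phenyl Group in Place of Methylsulfanyl

This account rests on a few compounds, and the source may have more. Where it says the series, first, only, none or still open, it means among the compounds named here.

Compound 1 has the structure `COc1ccccc1NC(=S)N1CCc2c(sc(NC(=O)c3ccccc3Cl)c2C(N)=O)C1`. In a functional assay on HeLa cells (Homo sapiens) for antiproliferative activity, with a stated time of 24 h (on this read-out lower numbers stand for stronger inhibition and higher numbers for weaker inhibition), compound 1 reports only > 50000 nM, which is a limit of the assay rather than a number (the limit of > 50000 nM in this assay, at which 1 of the 2 values shown sits). Among the compounds with values here, compound 2, `CSc1ccccc1NC(=S)N1CCc2c(sc(NC(=O)c3ccccc3Cl)c2C(N)=O)C1`, carries methylsulfanyl where compound 1 carries methoxy, and in this assay compound 2 gives 43600 nM, the only number in the set. The measured step of an at least 1.1-fold lower number from compound 1 to compound 2 (0.05 log units; that floor lies within the scatter) cannot be sized beyond its floor, which lies within the scatter. Compound 3, `NC(=O)c1c(NC(=O)c2ccccc2Cl)sc2c1CCN(C(=S)Nc1ccccc1-c1ccccc1)C2`, differs from compound 2 by phenyl in place of methylsulfanyl on an aromatic carbon. Within the data shown here, the single measured step exchanged one small group for another on the same aromatic carbon and gives little guidance on a phenyl entering there, so no step beyond the scatter is expected in this assay. For compound 3 the estimated value is 30000 nM, within a range from 8000 nM to 100000 nM. The expected step is a 1.5-fold lower number from compound 2 to compound 3 (0.16 log units; within the scatter).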

Compound 3, half-maximal inhibitory concentration: 24000 nM
Compound 3: the middle estimate sits 1.3-fold (0.10 log units) above what was measured; the range from low to high includes it.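

Putting phenyl in place of methylsulfanyl on this aromatic carbon brings in a ring where there was none, and the result is a 1.8-fold lower number from compound 2 to compound 3 (0.26 log units; within the scatter), so in this assay the position accepts a phenyl with no change that can be told from the scatter. Phenyl in place of methoxy gives an at least 2.0-fold lower number from compound 1 to compound 3 (0.31 log units; beyond the scatter), the first step in the set to clear the scatter, although it can be read only as a floor. Compound 1 stands at a limit of the assay and not at a number: the limit of > 50000 nM in this assay, at which 1 of the 3 values shown sits.

On these data alone, whether an amine or a carboxylic acid on this same aromatic carbon would shift the number remains open. So does whether a phenyl bearing a fluorine or a methoxy of its own would behave like the unsubstituted phenyl.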